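Swapping one halogen for another on the amide-side ring

The compounds below may be only part of what the source reports. "The series", "measured", "known", "first", "only" and "open" are said of these compounds alone.

Measured so far:
- compound 1 `O=C(CSc1nc(Nc2ccccc2)c2ccccc2n1)Nc1cccc([N+](=O)[O-])c1`: 11800 nM
- compound 2 `O=C(CSc1nc(Nc2ccccc2)c2ccccc2n1)Nc1ccc(F)cc1`: 9560 nM
- compound 3 `O=C(CSc1nc(Nc2ccccc2)c2ccccc2n1)Nc1ccc(Cl)c(Cl)c1`: 12100 nM

All three share one core and differ only in the ring on the amide nitrogen. In a functional assay on PC-3 cells (Homo sapiens) for inhibition, read by MTT assay, with a stated time of 72 h (a higher number here means a weaker inhibitor, a lower number a stronger inhibitor), compound 3 stands level with the others: a 1.0-fold higher number from compound 1 to compound 3 (0.01 log units; within the scatter) and a 1.3-fold higher number from compound 2 to compound 3 (0.10 log units; within the scatter). The remaining step is likewise small, a 1.2-fold lower number from compound 1 to compound 2 (0.09 log units; within the scatter).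

Compound 4 `O=C(CSc1nc(Nc2ccccc2)c2ccccc2n1)Nc1ccc(F)c(Cl)c1` carries fluoro in place of chloro on an aromatic carbon. Every change of this ring seen so far left this assay unmoved, so no step beyond the scatter is expected here either. The step from compound 3 to compound 4 is estimated as a 1.1-fold lower number from compound 3 to compound 4 (0.04 log units; within the scatter). For compound 4 the expected value is 11000 nM, with a range from 5500 nM to 24000 nM.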

Compound 4, half-maximal inhibitory concentration: 15500 nM
For compound 4 the middle estimate is 1.4-fold (0.15 log units) below the measured one; the measured number falls inside the stated range.
By their numbers in this assay, from the lowest: compounds 2, 1, 3 and 4 (each within the scatter of the next).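

Even the smallest edits to this ring leave this assay unmoved: a single halogen exchange, fluoro for chloro, gives (a 1.3-fold higher number from compound 3 to compound 4 (0.11 log units; within the scatter)), and chloro in place of hydrogen on the 4-fluorophenyl ring gives (a 1.6-fold higher number from compound 2 to compound 4 (0.21 log units; within the scatter)). The larger change from 3-nitrophenyl to 3-chloro-4-fluorophenyl gives the same flat picture (a 1.3-fold higher number from compound 1 to compound 4 (0.12 log units; within the scatter)). Nothing available explains this flat response. Still open, going by these compounds, is whether an amine or a carboxylic acid on this ring, or a longer chain in its place, would shift the number beyond the scatter.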